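Cytotoxicity notes: benzyl ring halogenation on the sulfonamide arm

A few compounds are considered here, and "the series" means these few. Any claim that something is new, unique, unknown or untested is made for them only; others in the source may bear on it.

Three analogues of the shared core have been run in a functional assay on MRC5 cells (Homo sapiens); a lower number here means that less compound is tolerated, a higher number that more compound is tolerated. Compound 1 `O=C1c2ccccc2N(Cc2ccc([N+](=O)[O-])cc2)S(=O)(=O)N1Cc1ccccc1` returns only the assay limit, > 59000 nM. Compound 2 `O=C1c2ccccc2N(Cc2ccccc2)S(=O)(=O)N1Cc1ccccc1` gives 66000 nM. Compound 3 `O=C1c2ccccc2N(Cc2ccccc2Cl)S(=O)(=O)N1Cc1ccccc1` gives 60000 nM, and with compound 2 it sits within the scatter: a 1.1-fold lower number from compound 2 to compound 3 (0.04 log units; within the scatter). The steps a step that the limit leaves unreadable from compound 1 to compound 2 and a step that the limit leaves unreadable from compound 1 to compound 3 cannot be sized, since the value of compound 1 is a limit (the limit of > 59000 nM in this assay, at which 1 of the 3 values shown sits).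

Compound 4 `O=C1c2ccccc2N(Cc2ccc(Cl)c(Cl)c2)S(=O)(=O)N1Cc1ccccc1` differs from compound 3 by 3,4-dichlorophenyl in place of 2-chlorophenyl on a saturated chain carbon bound to a sulfonamide nitrogen in a ring. Going by the values given here, the only readable step that bears on ring chlorination, from compound 2 to compound 3, lay within the scatter, so no step beyond the scatter is expected in this assay. The estimated step from compound 3 to compound 4 is a 1.2-fold lower number from compound 3 to compound 4 (0.06 log units; within the scatter). Compound 4 is expected to give 52000 nM, in the range 25000 nM to 90000 nM.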

Compound 4, half-maximal cytotoxic concentration: 56000 nM
The estimate for compound 4 lay 1.1-fold (0.03 log units) below the measured number, and the stated range covers the measured number.
By their numbers in this assay, from the lowest: compounds 4, 3 and 2 (each within the scatter of the next).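

In this assay the 3,4-dichlorophenyl group on this saturated chain carbon gives a 1.1-fold lower number from compound 3 to compound 4 (0.03 log units; within the scatter) against 2-chlorophenyl and a 1.2-fold lower number from compound 2 to compound 4 (0.07 log units; within the scatter) against phenyl, so a second chlorine adds no step beyond the scatter. Against 4-nitrophenyl there is only a floor, an at least 1.0-fold lower number from compound 1 to compound 4 (0.02 log units; that floor lies within the scatter) and no more, and the other steps from compound 1 cannot be read: the limit of > 59000 nM in this assay, at which 1 of the 4 values shown sits. Still open, as far as these compounds go, is whether an amine or a carboxylic acid on this aromatic ring, or a longer chain in place of the saturated chain carbon, would give a number beyond the scatter.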